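A few compounds are considered here, and "the series" means these few. Any claim that something is new, unique, unknown or untested is made for them only; others in the source may bear on it.

Within the data shown here, in a functional assay on A549 cells (Homo sapiens) for antiproliferative activity, read by MTT assay, with a stated time of 48 h (a lower number here means a stronger inhibitor, a higher number a weaker inhibitor), compound 3 (`COc1ccc(N(C)c2cc(C)nc(C)n2)cc1Cl`) gives 780 nM and sits in the middle of the three numbers known so far. Compound 2 (`COc1ccc(N(C)c2cc(C)nc(C)n2)cc1`) gives 277 nM on the low side, and compound 1 (`COc1ccc(N(C)c2ccnc(Cl)n2)cc1OCCC[Se]C#N`) gives 3710 nM on the high side, though compound 1 differs from the other two in more than one place. Compound 4 (`COc1ccc(N(C)c2cc(C)nc(C)n2)cc1O`) is compound 3 with a single change, hydroxy in place of chloro on an aromatic carbon, ortho to a methoxy group (hydroxy in place of chloro on an aromatic carbon). Among the measured compounds shown here, only one measured step bears on this: a 2.8-fold higher number from compound 2 to compound 3 (0.45 log units; beyond the scatter) with chloro in place of hydrogen on that same carbon, and it is modest. Removing the chloro may give back part of that step, although no hydroxy at this carbon has been measured. In this assay a modest step toward a lower number is therefore expected, estimated as a 2.1-fold lower number from compound 3 to compound 4 (0.31 log units; beyond the scatter) overall. For compound 4 the estimated value is 380 nM with an expected range from 130 nM to 1100 nM in this assay.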

Compound 4, half-maximal inhibitory concentration: 113 nM
Compound 4: middle estimate off by 3.4-fold (0.53 log units), on the high side; measured number outside the range, below it.
By their numbers in this assay, from the lowest: compound 4; then compound 2; then compound 3; then compound 1.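

In this assay, this carbon responds in both directions: chloro raised the number, while hydroxy at the same carbon gives a 6.9-fold lower number from compound 3 to compound 4 (0.84 log units; beyond the scatter) and so more than reverses that rise. The hydroxy does not merely return the compound to the level seen with hydrogen, as a 2.5-fold lower number from compound 2 to compound 4 (0.39 log units; beyond the scatter) shows that it goes clearly past it. A group at this carbon therefore need not cost potency, and among hydrogen, chloro and hydroxy the order runs with hydroxy giving the lowest number and chloro the highest.

No measurement shown here gives a reason for this order. As far as these compounds go, whether the gain needs the hydroxy itself remains open, and a second methoxy group or an amine at this carbon would help separate the possibilities.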